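The compounds below may be only part of what the source reports. "The series", "measured", "known", "first", "only" and "open" are said of these compounds alone.

Compound 1 `C#CCN(Cc1ccc2ncnc(S)c2c1)c1ccc(C(=O)NC(CCC(=O)O)C(=O)O)cc1` is the starting point. For the measured compounds named here, in a functional assay on L1210 cells for inhibition of Thymidylate synthase (Mus musculus) (a lower number here means a stronger inhibitor, a higher number a weaker inhibitor), compound 1 gives 110 nM, the higher of the two numbers measured so far, so it is the weaker of the two inhibitors. Going by the values given here, compound 2 `C#CCN(Cc1ccc2nc(N)nc(S)c2c1)c1ccc(C(=O)NC(CCC(=O)O)C(=O)O)cc1` carries an amino group on an aromatic carbon of the shared core; in this assay compound 2 gives 19 nM, and the change a 5.8-fold lower number from compound 1 to compound 2 (0.76 log units; beyond the scatter) is the only measured step. Compound 3 `CCN(Cc1ccc2ncnc(S)c2c1)c1ccc(C(=O)NC(CCC(=O)O)C(=O)O)cc1` has not yet been measured. It differs from compound 1 by methyl in place of ethynyl on a saturated chain carbon bound to a nitrogen on an aromatic ring; read one bond further out, the propargyl chain becomes an ethyl chain. Among the compounds with values here, the one measured step concerns a different part of the molecule, the amino group on the core, and says nothing about shortening this chain, so there is no direct guide. A step beyond the scatter in either direction is possible, with a weaker inhibitor somewhat the more likely outcome. The change expected on this basis is a 2.3-fold higher number from compound 1 to compound 3 (0.36 log units; beyond the scatter). The estimate for compound 3 in this assay is 250 nM, expected to fall between 80 nM and 800 nM.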

Compound 3, half-maximal inhibitory concentration: 260 nM
Compound 3: the middle estimate sits 1.0-fold (0.02 log units) below what was measured; measured number inside the range.
By their numbers in this assay, from the lowest: compound 2; then compound 1; then compound 3.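

For the compounds shown here, this is the first reading on the chain at the nitrogen: in this assay, going from propargyl to ethyl, which puts methyl in place of ethynyl on a saturated chain carbon bound to a nitrogen on an aromatic ring, gives a 2.4-fold higher number from compound 1 to compound 3 (0.37 log units; beyond the scatter). So activity depends on this chain as well as on the amino group on the core, the only place the earlier step had tested, and within this pair the propargyl chain gives the stronger inhibitor. The change removes the triple bond and shortens the chain at once, so this pair cannot tell which of the two matters, and no measured evidence explains the difference.

A propyl chain, which has no triple bond but is longer than ethyl, would help separate chain length from the triple bond, and an allyl chain or a longer chain ending in a triple bond would test the same question from other directions. Going by these compounds, it also remains open whether swapping propargyl for ethyl would have a similar effect on the amino-bearing core of compound 2.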